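Trimming a Nitrobenzyl Ether Down to an Ethyl Ether

The source may report more compounds than this note shows. Statements on the series, on what has been measured and on what is new or still open speak of the compounds shown alone.

For the measured compounds named here, compound 1 `O=[N+]([O-])c1cccc(COc2ccc(OCCOCCNC3CCCC3)cc2)c1` is one of only two compounds measured in a functional assay on SK-OV-3 cells (Homo sapiens) for inhibition, read by CCK-8 assay, with a stated time of 70 h (on this read-out higher numbers stand for weaker inhibition and lower numbers for stronger inhibition), where compound 1 gives 15400 nM. Its companion compound 2 `c1ccc(COc2ccc(OCCOCCNC3CCC3)cc2)cc1` gives 25000 nM in this assay; the two numbers lie within the scatter of each other, so neither stands apart. Compound 3 `CCOc1ccc(OCCOCCNC2CCCC2)cc1` has not yet been measured. It differs from compound 1 in one place: methyl in place of 3-nitrophenyl on a saturated chain carbon bound to an oxygen on an aromatic ring. Going by the values given here, no measured pair shows what this kind of change does here. Since the 3-nitrophenyl is lost, inhibition is expected to weaken somewhat, giving a step of a 2.3-fold higher number from compound 1 to compound 3 (0.36 log units; beyond the scatter). Compound 3 is therefore estimated at 35000 nM, between 12000 nM and 100000 nM.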

Compound 3, half-maximal inhibitory concentration: 90500 nM
Compound 3: middle estimate off by 2.6-fold (0.41 log units), on the low side, within the range that was stated.
By their numbers in this assay, from the lowest: compounds 1 and 2 (each within the scatter of the next); then compound 3.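

Putting methyl in place of 3-nitrophenyl on a saturated chain carbon bound to an oxygen on an aromatic ring gives a 5.9-fold higher number from compound 1 to compound 3 (0.77 log units; beyond the scatter) in this assay. For the compounds shown here, this is the first step here that lies beyond the scatter, so inhibition does depend on what sits at this position. No available measurement gives a reason for the loss.

On these data alone, the change removes the aromatic ring and the nitro group together, so their separate shares remain unknown. As far as these compounds go, whether a 3-aminophenyl group or a longer alkyl chain would keep inhibition also remains open.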